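Fluorine on the Phenyl Group in a Triazole Series

The source may hold more compounds than are shown below. What is called first, only, known or untested is meant among the compounds shown, and "the series" means these compounds.

Of the compounds shown here, three have been tested in a functional assay on SW480 cells (Homo sapiens) for cytotoxicity, read by MTT assay, with a stated time of 4 days (a higher number here means a weaker inhibitor, a lower number a stronger inhibitor), and a fourth awaits its result. Compound 1 `C=C1C[C@]23C[C@@]1(O)CC[C@H]2c1cc(Br)c(O)c(C)c1[C@@H]3Cn1cc(-c2ccccc2)nn1` carries a plain phenyl group on the triazole. In this assay compound 1 gives > 20000 nM, which is a limit of the assay and not a number. Compound 2 `C=C1C[C@]23C[C@@]1(O)CC[C@H]2c1cc(Br)c(O)c(C)c1[C@@H]3Cn1cc(-c2ccc(F)cc2)nn1` differs from compound 1 by a single change, (fluoro in place of hydrogen on an aromatic carbon). In this assay compound 2 gives > 20000 nM, again a limit of the assay. The step between the two, a step that the two limits leave unreadable from compound 1 to compound 2, cannot be read because both values sit at the limit of > 20000 nM in this assay, at which 3 of the 3 values shown sit.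

Compound 3 `C=C1C[C@]23C[C@@]1(O)CC[C@@H]2c1cccc(C)c1[C@@H]3Cn1cc(-c2ccccc2)nn1` stands on a different core; the difference between the two cores is not broken down here. In this assay compound 3 gives > 20000 nM, once more a limit of the assay. Compound 4 `C=C1C[C@]23C[C@@]1(O)CC[C@@H]2c1cccc(C)c1[C@@H]3Cn1cc(-c2ccc(F)cc2)nn1` is the unmeasured member. It differs from compound 3 by fluoro in place of hydrogen on an aromatic carbon, which is the same change as that from compound 1 to compound 2, at the same place.

Compound 4 is expected to give about 30000 nM in this assay, most probably reported again as a limit. That expectation rests on compound 3 giving > 20000 nM. The step this estimate implies, a step that the limit leaves unreadable from compound 3 to compound 4, is expected to be small because the matching step that the two limits leave unreadable from compound 1 to compound 2 left no readable change, and because every measured value sits at the limit of > 20000 nM in this assay, at which 3 of the 3 values shown sit.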

Compound 4, half-maximal inhibitory concentration: > 20000 nM
Compound 4: no number, only a limit; the forecaster's own chance of this, stated with the estimate: 85%; the middle value lies beyond the limit too.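

No step can be read between compound 3 and compound 4, the change from phenyl to 4-fluorophenyl, because both values are limits of the assay and not numbers: the limit of > 20000 nM in this assay, at which 4 of the 4 values shown sit.

The compounds shown leave open how strongly any of the four acts in this assay, and whether fluoro in place of hydrogen makes any difference on either core.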